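A few compounds are considered here, and "the series" means these few. Any claim that something is new, unique, unknown or untested is made for them only; others in the source may bear on it.

In a functional assay on CCRF-CEM cells (Homo sapiens) (on this read-out lower numbers stand for higher toxicity in this test and higher numbers for lower toxicity in this test), compound 1 `Cc1cn([C@@H]2O[C@H](CO[Si](C)(C)C(C)(C)C)[C@@]3(OS(=O)(=O)C=C3N)[C@H]2O[Si](C)(C)C(C)(C)C)c(=O)n(CCO)c1=O` gives 11300 nM, and compound 2 `Cc1cn([C@@H]2O[C@H](CO[Si](C)(C)C(C)(C)C)[C@@]3(OS(=O)(=O)C=C3N)[C@H]2O[Si](C)(C)C(C)(C)C)c(=O)n(CCCCO)c1=O` gives 20500 nM. Going by the values given here, these two values lie within the usual scatter of each other, so compound 2 stands level with the only other measured compound. Compound 3 `Cc1cn([C@@H]2O[C@H](CO[Si](C)(C)C(C)(C)C)[C@@]3(OS(=O)(=O)C=C3N)[C@H]2O[Si](C)(C)C(C)(C)C)c(=O)n(CCCNC(=O)OCc2ccccc2)c1=O` keeps the shared core but has not yet been measured. Its difference from compound 2 is this: (benzyloxycarbonyl)amino in place of hydroxymethyl on a saturated chain carbon, three bonds along the chain from an aromatic nitrogen. Put simply, (benzyloxycarbonyl)amino stands in place of hydroxymethyl on a saturated chain carbon, three bonds along the chain from an aromatic nitrogen.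

Among the compounds with values here, only one measured step bears on this change: a 1.8-fold higher number from compound 1 to compound 2 (0.26 log units; within the scatter). It also alters the chain on that aromatic nitrogen, and it stays within the scatter. It is only a weak guide, as neither measured compound carries a benzyloxycarbonyl group or a second aromatic ring, and the data give no firm direction. With that single small step as the guide, the expected change is a 1.5-fold lower number from compound 2 to compound 3 (0.17 log units; within the scatter), which means no expected step beyond the scatter. The estimate for compound 3 is 14000 nM, with an expected range from 5000 nM to 40000 nM.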

Compound 3, half-maximal cytotoxic concentration: 229000 nM
For compound 3 the middle estimate is 16-fold (1.21 log units) below the measured one; the whole stated range lies below it.
By their numbers in this assay, from the lowest: compounds 1 and 2 (each within the scatter of the next); then compound 3.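

Going by these compounds alone, until this result, changes to the chain on this aromatic nitrogen had stayed within the scatter, so the position looked insensitive to what sat at the chain's end. In this assay, placing (benzyloxycarbonyl)amino on this saturated chain carbon gives an 11-fold higher number from compound 2 to compound 3 (1.05 log units; beyond the scatter) and the comparison with the shorter hydroxy-ended chain gives a 20-fold higher number from compound 1 to compound 3 (1.31 log units; beyond the scatter) so the position does respond to a change of group, and this change moves the number towards lower toxicity in this test. Nothing measured here explains this large step.

The compounds shown leave open which part of the (benzyloxycarbonyl)amino group accounts for the step: the six-membered aromatic ring, the carbonyl, or simply the larger size of the group as a whole. A plain amine or an acetamide at the end of the same chain could help separate these parts, while a longer chain ending in (benzyloxycarbonyl)amino could show whether the group's distance from the aromatic nitrogen matters as well.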